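Swapping ortho substituents on the benzylidene arm

The source may hold more compounds than are shown below. What is called first, only, known or untested is meant among the compounds shown, and "the series" means these compounds.

Measured so far:
- compound 1 `O=C1/C(=C/c2ccccc2Cl)c2ccccc2N1c1c(Cl)cccc1Cl`: 15 ug/mL
- compound 2 `O=C1/C(=C/c2c(Cl)cccc2Cl)c2ccccc2N1c1c(Cl)cccc1Cl`: > 100 ug/mL

In a functional assay on SW-620 cells (Homo sapiens) for cytotoxicity, read by MTT assay, with a stated time of 3 days (on this read-out lower numbers stand for an effect already at smaller amounts and higher numbers for an effect only at larger amounts of compound), compound 1 gives 15 ug/mL. For compound 2 the result is only a limit of the assay, > 100 ug/mL, so compound 2 stands at the limit of > 100 ug/mL in this assay, at which 1 of the 2 values shown sits, and its true number is not known. Among the measured compounds shown here, the one measured step, an at least 6.6-fold higher number from compound 1 to compound 2 (0.82 log units; beyond the scatter), shows that the second chloro weakened the effect.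

Compound 3 `O=C1/C(=C/c2ccccc2[N+](=O)[O-])c2ccccc2N1c1c(Cl)cccc1Cl` carries 2-nitrophenyl in place of 2,6-dichlorophenyl on a double-bonded chain carbon bound to a double-bonded ring carbon. For the measured compounds named here, this change removes one of the two chloro groups that set compound 2 apart from compound 1 and replaces the other with a nitro group, for which no measured pair gives guidance. With the step from compound 1 to compound 2 as the only hint, compound 3 is expected to land nearer compound 1 than compound 2, which would mean an at least 3.3-fold lower number from compound 2 to compound 3 (0.52 log units; beyond the scatter). The estimate for compound 3 is 30 ug/mL, in a range from 8 ug/mL to 100 ug/mL.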

Compound 3, concentration for half-maximal effect: 90 ug/mL
The estimate for compound 3 lay 3.0-fold (0.48 log units) below the measured number; the range from low to high includes it.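

Nitro in place of chloro on an aromatic carbon gives a 6.0-fold higher number from compound 1 to compound 3 (0.78 log units; beyond the scatter), so on this arm the effect can weaken without a second chloro being added, and compound 1 keeps the lowest number of the three. The other comparison gives an at least 1.1-fold lower number from compound 2 to compound 3 (0.04 log units; that floor lies within the scatter), which means that 2-nitrophenyl and 2,6-dichlorophenyl at this place cannot be put in order. Compound 2 has only a limit and no true number: the limit of > 100 ug/mL in this assay, at which 1 of the 3 values shown sits.

On these data alone, whether an amine or a carboxylic acid in place of the chloro of compound 1 would keep or lower the number stays open. The rest of the core is the same in all three compounds, so what a change there would do is open as well.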